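A few compounds are considered here, and "the series" means these few. Any claim that something is new, unique, unknown or untested is made for them only; others in the source may bear on it.

Series notes, carbamate variation on the shared core. Compound 1 `CC(C)(C)OC(=O)N1CCC(Oc2ncnc3c2CCN3c2ccc(S(C)(=O)=O)cc2F)CC1` carries a tert-butyl carbamate and in a functional assay on CHO-K1 cells for agonist activity at Glucose-dependent insulinotropic receptor (Homo sapiens), read by a luciferase reporter, with a stated time of 5 h (a lower number here means that less compound is needed, a higher number that more compound is needed for the effect), compound 1 gives 20 nM. Compound 2 `CCCOC(=O)N1CCC(Oc2ncnc3c2CCN3c2ccc(S(C)(=O)=O)cc2F)CC1` carries a propyl carbamate and in this assay compound 2 gives 79.4 nM. Within the data shown here, the one step so far, a 4.0-fold higher number from compound 1 to compound 2 (0.60 log units; beyond the scatter), goes in the direction of a higher number. Among the measured compounds shown here, compound 2 therefore stands at the highest of the two numbers in hand, with compound 1 as its only neighbour.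

Compound 3 `CC(C)COC(=O)N1CCC(Oc2ncnc3c2CCN3c2ccc(S(C)(=O)=O)cc2F)CC1` is the next entry. The change from compound 2 is methyl in place of hydrogen on a saturated chain carbon bound to two saturated chain carbons, which reads propyl to isobutyl, or propoxy to isobutoxy, at the carbamate oxygen. For the measured compounds named here, the only step that bears on it is the one from tert-butyl to propyl, a 4.0-fold higher number from compound 1 to compound 2 (0.60 log units; beyond the scatter), modest in size and beyond the scatter. Isobutyl sits between propyl and tert-butyl in its make-up, so a step back toward a lower number is expected, though not the full return, because compound 1 gives 20 nM and the step here is smaller. The expected step is a 1.6-fold lower number from compound 2 to compound 3 (0.20 log units; within the scatter). Compound 3 is estimated at 50 nM, with a range from 20 nM to 125 nM.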

Compound 3, half-maximal effective concentration: 25.1 nM
Compound 3: the middle estimate sits 2.0-fold (0.30 log units) above what was measured; low and high end bracket the measured number.
By their numbers in this assay, from the lowest: compounds 1 and 3 (each within the scatter of the next); then compound 2.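

In this assay, methyl in place of hydrogen on a saturated chain carbon bound to two saturated chain carbons is a single added carbon, yet it gives a step beyond the scatter (a 3.2-fold lower number from compound 2 to compound 3 (0.50 log units; beyond the scatter)), so the carbamate chain responds to a very small change at this carbon. The isobutyl and tert-butyl carbamates cannot be told apart here (a 1.3-fold higher number from compound 1 to compound 3 (0.10 log units; within the scatter)), so among these three compounds the two branched chains stand together, while the unbranched propyl of compound 2 stands alone at the higher number. No measurement in hand gives a reason for the propyl to isobutyl step.

With only one unbranched chain in the set, branching and chain size cannot be separated, and a longer unbranched chain such as butyl or pentyl, or a cyclic group such as cyclobutyl or cyclopropylmethyl, would test this on the carbamate oxygen. Going by these compounds, how far the result depends on the carbamate itself also remains open, and a urea carrying an amine nitrogen in place of that oxygen, or an amide, would address this on the shared core.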